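Cinnamoyl serine esters: methyl for methoxy on Vero cells

The compounds below may be only part of what the source reports. "The series", "measured", "known", "first", "only" and "open" are said of these compounds alone.

Compound 1, `COC(=O)[C@H](CO)NC(=O)/C=C/c1ccc(F)cc1`: "not determined" (no result reported)
Compound 2, `COC(=O)[C@H](CO)NC(=O)/C=C/c1ccc(OC)cc1`: 100%

Going by the values given here, in an ADME assay on Vero cells (Chlorocebus sabaeus) for cytotoxicity, read by WST assay, tested at 50 ug/mL (on this read-out lower numbers stand for a stronger effect and higher numbers for a weaker effect at the one concentration tested), compound 2 gives 100%, the only number available; for compound 1 no result was reported in this assay. Compound 3, `COC(=O)[C@H](CO)NC(=O)/C=C/c1ccc(C)cc1`, differs from compound 2 by methyl in place of methoxy on an aromatic carbon. Among the compounds with values here, no step between measured compounds exists to set the size of this change. Because compound 2 gives 100% in this assay, the step of a number 2 percentage points lower from compound 2 to compound 3 (within the scatter) is expected to be none beyond the scatter. Compound 3 is therefore estimated at 98%, between 85% and 110%.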

Compound 3, a percentage reported as activity, at one concentration (the size of the read-out at that concentration, not a potency): 100%
Compound 3: the middle estimate sits 2 percentage points below what was measured, within the range that was stated.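

In this assay, going by these compounds alone, the exchange of methoxy for methyl on the aromatic carbon gives the first measured step at this position (no change at the digits printed from compound 2 to compound 3 (within the scatter)). It shows that, on the shared core, this read-out does not separate a group with one hydrogen-bond acceptor from one with none at this place. Nothing available explains this result. From the compounds shown here alone, whether an amine, a carboxylic acid or a longer chain at this place would stay level with compound 2 and compound 3 remains open. So does whether any group here gives a step beyond the scatter.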